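Branched ether in place of branched amine on the shared core

This account rests on a few compounds, and the source may have more. Where it says the series, first, only, none or still open, it means among the compounds named here.

Three compounds share one core and differ only in the group carried on one aromatic carbon. In an in vitro assay on 293-EBNA cells for binding affinity to corticotropin-releasing factor receptor 1 (Homo sapiens) (on this read-out lower numbers stand for stronger inhibition and higher numbers for weaker inhibition), compound 1 `CCN(CC)c1nc(C)nc2c1nnn2-c1ccc(C(C)C)cc1Br` gives 25.3 nM. Compound 2 `CCCCNc1nc(C)nc2c1nnn2-c1ccc(C(C)C)cc1Br` gives 69.6 nM in this assay, and compound 3 `CCCCC(CCCC)Nc1nc(C)nc2c1nnn2-c1ccc(C(C)C)cc1Br` gives 4.5 nM. Compound 3 thus shows the lowest number of the three: the change from compound 1 to compound 3 was a 5.6-fold lower number from compound 1 to compound 3 (0.75 log units; beyond the scatter), and the change from compound 2 to compound 3 was a 15-fold lower number from compound 2 to compound 3 (1.19 log units; beyond the scatter), while the change from compound 1 to compound 2 was a 2.8-fold higher number from compound 1 to compound 2 (0.44 log units; beyond the scatter).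

Compound 4 `CCOCC(COCC)Oc1nc(C)nc2c1nnn2-c1ccc(C(C)C)cc1Br` is built from compound 3 by the change (a group of 10 heavy atoms (7 carbon, 3 oxygen; no ring) in place of a group of 10 heavy atoms (9 carbon, 1 nitrogen; no ring), on an aromatic carbon). The new group keeps a branched chain of the same count but carries oxygen instead of nitrogen, with no hydrogen-bond donor left. Going by the values given here, the measured steps bear only on chain length and branching, where a larger branched chain brought the clearly lower numbers seen from compound 2 to compound 3 and from compound 1 to compound 3; no measured step tests the exchange of nitrogen for oxygen. Compound 4 is therefore expected to stay closer to compound 3 than to compound 2, with a modest rise estimated as a 3.3-fold higher number from compound 3 to compound 4 (0.52 log units; beyond the scatter). The estimate for compound 4 in this assay is 15 nM, within a range from 3 nM to 80 nM.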

Compound 4, inhibition constant: 39.7 nM
Beside the measured number, compound 4's estimate is 2.6-fold (0.42 log units) below it; low and high end bracket the measured number.
By their numbers in this assay, from the lowest: compound 3; then compounds 1, 4 and 2 (each within the scatter of the next, the first and the last beyond it).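

In this assay, exchanging one branched group for another of the same heavy-atom count at this aromatic carbon gives an 8.8-fold higher number from compound 3 to compound 4 (0.95 log units; beyond the scatter), so that count and branching alone do not preserve the low number of the branched amine. The branched ether also stands apart from the two smaller amino groups by no more than the usual scatter, with a 1.8-fold lower number from compound 2 to compound 4 (0.24 log units; within the scatter) and a 1.6-fold higher number from compound 1 to compound 4 (0.20 log units; within the scatter) on the two comparisons, so the larger size of its group brings no measurable gain over either butylamino or diethylamino. The change replaces the nitrogen on the aromatic carbon with oxygen, places further oxygen in the chain and leaves no hydrogen-bond donor, and no available evidence assigns the higher number to any of these differences.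

These alterations remain tied together in the compounds shown, so the contribution of each one stays open. A 1-butylpentyl chain joined through oxygen would test the linking atom alone, while an amine carrying the same two ethoxymethyl branches would test the oxygen in the chain.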